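A few compounds are considered here, and "the series" means these few. Any claim that something is new, unique, unknown or untested is made for them only; others in the source may bear on it.

Measured so far in an ADME assay on HEK293 cells (Homo sapiens) for cytotoxicity, with a stated time of 72 h; on this read-out higher numbers stand for an effect only at larger amounts of compound and lower numbers for an effect already at smaller amounts:
- Compound 1 `C=C[C@@](C)(/C=C/c1ccc(OS(=O)(=O)c2ccc(C)cc2)cc1)CCC=C(C)C`: > 36600 nM, a limit
- Compound 2 `C=C[C@@](C)(/C=C/c1ccc(O)c(CO)c1)CCC=C(C)C`: > 36600 nM, a limit
- Compound 3 `CC(C)=CCC[C@@](C)(/C=C/c1ccccc1)/C=C/c1ccc(O)cc1`: > 36600 nM, a limit

Compound 3 has no numerical value, and its result is a limit only. For the measured compounds named here, it shares that position with the other two compounds, and the series so far offers only (the limit of > 36600 nM in this assay, at which 3 of the 3 values shown sit). Going by the values given here, no measured step between two compounds is available, so the effect of a single structural change in this assay remains unknown.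

Compound 4 `CC(C)=CCC[C@](C)(/C=C/c1ccc(O)cc1)/C=C/c1cccc(Cl)c1` follows from compound 3 by one change, phenyl to 3-chlorophenyl: chloro in place of hydrogen on an aromatic carbon. With chloro in place of hydrogen on an aromatic carbon, no step beyond the scatter is expected, and a further result at the limit is the likeliest outcome. The expected step is a number no higher from compound 3 to compound 4 (the limit leaves the size open). For compound 4, the estimated value is 36600 nM, with an expected range of 15000 nM to 70000 nM.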

Compound 4, half-maximal effective concentration: > 36600 nM
Compound 4: a limit, no number (the forecaster's own chance of this, stated with the estimate: 75%); the middle value sits exactly at the limit.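

For the compounds shown here, the results for compound 3 and compound 4 are both limits, and no step between them can be read. The compounds shown leave open what chloro in place of hydrogen on an aromatic carbon does in this assay, and whether any of them gives a number there: the limit of > 36600 nM in this assay, at which 4 of the 4 values shown sit.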